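Ethoxy to benzyloxy on the series core

The source may hold more compounds than are shown below. What is called first, only, known or untested is meant among the compounds shown, and "the series" means these compounds.

In an ADME assay on Vero cells (Chlorocebus sabaeus) for cytotoxicity, read by MTT assay, with a stated time of 72 h (on this read-out lower numbers stand for stronger inhibition and higher numbers for weaker inhibition), compound 1 (`CC(=O)c1c(C)[n+]([O-])c2cc(-n3ccnc3)c(F)cc2[n+]1[O-]`) gives 95700 nM and compound 2 (`CCOC(=O)c1c(C)[n+]([O-])c2cc(-n3ccnc3)c(F)cc2[n+]1[O-]`) gives 129000 nM while compound 3 (`CCOC(=O)c1c(C)[n+]([O-])c2cc(-n3cncn3)c(F)cc2[n+]1[O-]`) gives 155000 nM on the same read-out. Compound 2 holds the middle number, within the scatter of both others. Compound 4 (`Cc1c(C(=O)OCc2ccccc2)[n+]([O-])c2cc(F)c(-n3ccnc3)cc2[n+]1[O-]`) differs from it thus: phenyl in place of methyl on a saturated chain carbon bound to an oxygen next to a carbonyl group. For the measured compounds named here, two measured steps bear on this: a 1.3-fold higher number from compound 1 to compound 2 (0.13 log units; within the scatter) at the same carbonyl and a 1.2-fold higher number from compound 2 to compound 3 (0.08 log units; within the scatter) at an aromatic carbon. Neither leaves the scatter, so no step beyond it is expected in this assay here. The expected change is a 1.2-fold lower number from compound 2 to compound 4 (0.09 log units; within the scatter) in this estimate. Compound 4 is estimated at 105000 nM with a range of 50000 nM to 200000 nM as expected limits.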

Compound 4, half-maximal inhibitory concentration: 107000 nM
Estimate against measurement, compound 4: 1.0-fold (0.01 log units) below, and the stated range covers the measured number.
By their numbers in this assay, from the lowest: compounds 1, 4, 2 and 3 (each within the scatter of the next).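

In this assay, phenyl in place of methyl on the saturated chain carbon bound to an oxygen next to a carbonyl group gives a 1.2-fold lower number from compound 2 to compound 4 (0.08 log units; within the scatter) and so adds a six-membered aromatic ring without a step beyond the scatter. Benzyloxy in place of methyl on the carbonyl carbon gives a 1.1-fold higher number from compound 1 to compound 4 (0.05 log units; within the scatter) and is likewise no step beyond the scatter. No measurement shown accounts for these small steps.

Still open, going by these compounds, is whether a carboxylic acid or an amide at this carbonyl carbon would leave the scatter. Also open, on these data alone, is whether an amine on the benzyl ring would do so.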